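The compounds below may be only part of what the source reports. "The series", "measured", "known", "first", "only" and "open" are said of these compounds alone.

Series notes. Three analogues built on the shared core of compound 1 `Cc1ncnc2[nH]cc(Sc3cccs3)c12` have been run in a functional assay on CCRF-CEM cells (Homo sapiens), read by MTT assay, with a stated time of 3 days; on this read-out lower numbers stand for stronger inhibition and higher numbers for weaker inhibition. Compound 1 returns only a limit of the assay, > 50000 nM. Compound 2 `c1coc(-c2ncnc3[nH]cc(Sc4cccs4)c23)c1` gives 7730 nM in this assay, and compound 3 `Nc1ncnc2[nH]cc(Sc3cccs3)c12` gives 16700 nM. Among the two numbers actually read, compound 3 stands as the higher, the step of a 2.2-fold higher number from compound 2 to compound 3 (0.33 log units; beyond the scatter) being modest but beyond the scatter; the steps of an at least 6.4-fold lower number from compound 1 to compound 2 (0.81 log units; beyond the scatter) and an at least 2.9-fold lower number from compound 1 to compound 3 (0.47 log units; beyond the scatter) are bounded on one side by the limit (the limit of > 50000 nM in this assay, at which 1 of the 3 values shown sits).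

Compound 4 `CNc1ncnc2[nH]cc(Sc3cccs3)c12` differs from compound 3 only by methyl in place of hydrogen on a nitrogen on an aromatic ring. Within the data shown here, all three measured steps concern the group on the aromatic carbon; none alters what sits on that nitrogen, so no measured step bears directly on this change. No direction can be drawn from them, and in this assay the step is expected to stay within the scatter. Compound 4 is therefore estimated at 13000 nM, with a range from 4500 nM to 40000 nM. For compound 4 the step expected is a 1.3-fold lower number from compound 3 to compound 4 (0.11 log units; within the scatter).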

Compound 4, half-maximal inhibitory concentration: 14700 nM
For compound 4 the middle estimate is 1.1-fold (0.05 log units) below the measured one; the range from low to high includes it.
By their numbers in this assay, from the lowest: compounds 2, 4 and 3 (each within the scatter of the next, the first and the last beyond it). At a limit, above all of these: compound 1.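

In this assay, the change on the nitrogen separates nothing: methylamino and amino cannot be told apart here (a 1.1-fold lower number from compound 3 to compound 4 (0.06 log units; within the scatter)). Methylamino in place of furan-2-yl on the aromatic carbon (a 1.9-fold higher number from compound 2 to compound 4 (0.28 log units; within the scatter)) leaves compound 4 within the scatter of compound 2, whereas compound 3 lies beyond the scatter of compound 2. Methylamino in place of methyl on the aromatic carbon (an at least 3.4-fold lower number from compound 1 to compound 4 (0.53 log units; beyond the scatter)) can be read only as a one-sided step, since compound 1 stands at a limit: the limit of > 50000 nM in this assay, at which 1 of the 4 values shown sits.

Still open, from the compounds shown here alone, is whether a larger group on that nitrogen, such as ethyl or benzyl, or a second methyl as in dimethylamino, would move the number beyond the scatter. Also open, going by these compounds, is how a carboxylic acid or a longer chain on the aromatic carbon would compare with furan-2-yl.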